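The source may hold more compounds than are shown below. What is called first, only, known or untested is meant among the compounds shown, and "the series" means these compounds.

Compound 1 `CCOc1ncc(-c2nc(C(F)(F)F)sc2N2CCN(C(=O)Cn3nc(C)nc3C)[C@H](C)C2)cn1` gives 364 nM in an assay on blood for inhibition of C-X-C chemokine receptor type 3 (Homo sapiens), with a stated time of 30 min; a lower number here means a stronger inhibitor, a higher number a weaker inhibitor.
Compound 2 `Cc1ncc(-c2nc(C(F)(F)F)sc2N2CCN(C(=O)Cn3nc(C)nc3C)[C@H](C)C2)cn1` gives 610 nM in this assay.

Compound 3 `CCc1ncc(-c2nc(C(F)(F)F)sc2N2CCN(C(=O)Cn3nc(C)nc3C)[C@H](C)C2)cn1` has not yet been measured in this assay.

For the measured compounds named here, only two numbers are known, and they sit close together: the step of a 1.7-fold higher number from compound 1 to compound 2 (0.22 log units; within the scatter) lies within the scatter, so compounds 1 and 2 cannot be told apart on these data. Compound 3 differs from compound 2 by methyl in place of hydrogen on a saturated chain carbon bound to an aromatic carbon. Going by the values given here, the one measured step touches the same part of the shared core, where ethoxy was replaced by methyl without a change beyond the scatter; the change from compound 2 to compound 3 is not the same exchange, and no measured pair reports the growth of methyl to ethyl. The only bearing the data have is that altering this group so far has not moved the number beyond the scatter, so a step in this assay of no more than the scatter, in either direction, is expected, a 1.2-fold lower number from compound 2 to compound 3 (0.09 log units; within the scatter). Compound 3 is therefore expected to give about 500 nM in this assay, with a range from 250 nM to 1000 nM.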

Compound 3, half-maximal inhibitory concentration: 567 nM
For compound 3 the middle estimate is 1.1-fold (0.05 log units) below the measured one; low and high end bracket the measured number.
By their numbers in this assay, from the lowest: compounds 1, 3 and 2 (each within the scatter of the next).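

Putting 2-ethylpyrimidin-5-yl in place of 2-methylpyrimidin-5-yl gives a 1.1-fold lower number from compound 2 to compound 3 (0.03 log units; within the scatter) in this assay and thus supplies the direct measurement of methyl to ethyl that was missing before; the step does not separate the two compounds. Ethyl in place of ethoxy on the same aromatic carbon gives a 1.6-fold higher number from compound 1 to compound 3 (0.19 log units; within the scatter) and likewise does not separate them, so ethoxy, methyl and ethyl all stand within the scatter of one another, and these three compounds show no dependence of the number on which of the groups is present. No measurement at hand offers an explanation for this sameness.

The compounds leave open whether any other group at this place would move the number beyond the scatter, for instance a longer chain such as butyl, a cyclopropyl ring, an amine or a carboxylic acid. They also leave open whether the flat result would hold with a different substituent elsewhere on the shared core, as all three compounds differ in this one place only.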